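Swapping One Ring Group in Compound 2

A few compounds are considered here, and "the series" means these few. Any claim that something is new, unique, unknown or untested is made for them only; others in the source may bear on it.

- Compound 1 `O=C(O)CC(NC(=O)CCCCc1ccc2c(n1)NCCC2)c1cncnc1`: 10%
- Compound 2 `O=C(O)C[C@H](CCCCCCc1ccc2c(n1)NCCC2)c1cncnc1`: 66%

These two numbers come from an in vivo ADME assay on the whole organism (Canis lupus familiaris) for pharmacokinetics; on this read-out higher numbers stand for higher oral bioavailability and lower numbers for lower oral bioavailability. Compound 2 holds the higher of the two, and its gap to compound 1 lies beyond the usual scatter of repeated measurements. The two compounds differ in more than one place, so that gap cannot be tied to any single change.

Compound 3 `O=C(O)C[C@H](CCCCCCc1ccc2c(n1)NCCC2)c1ccc2c(c1)OCC2` differs from compound 2 in one place: a group of 9 heavy atoms (8 carbon, 1 oxygen; one five-membered non-aromatic ring with 1 hetero atom, one six-membered aromatic ring of carbon only) in place of a group of 6 heavy atoms (4 carbon, 2 nitrogen; one six-membered aromatic ring with 2 hetero atoms), on a saturated chain carbon bound to two saturated chain carbons. Going by the values given here, no measured pair shows this kind of swap, so the expectation here is loose. Among the compounds with values here, with compound 2 at 66%, the higher of only two numbers, a moderate fall in this assay, beyond the scatter, seems more likely than a rise. The expected change is a number 26 percentage points lower from compound 2 to compound 3 (beyond the scatter). For compound 3 the estimated value is 40%, with an expected range of 15% to 70%.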

Compound 3, oral bioavailability: > 99%
Compound 3 ended at the assay's limit; the forecaster's own chance of this, stated with the estimate: 2%; middle value at least 59 percentage points away from the limit.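

In this assay, putting the two-ring group of 9 heavy atoms in place of pyrimidin-5-yl on this saturated chain carbon gives a number at least 33 percentage points higher from compound 2 to compound 3 (beyond the scatter) as its result. This position therefore accepts a larger group with no ring nitrogen and one hydrogen-bond acceptor instead of 2, with no loss on this read-out, something compound 1 and compound 2 could not show because they differ in more than one place. The reading of compound 3 is a limit and not a number, so the step gives only its smallest size: the limit of > 99% in this assay, at which 1 of the 3 values shown sits.

Going by these compounds, it stays open whether the whole entering group matters or only its six-membered aromatic ring of carbon. A plain phenyl ring, or a pyridine ring with a single nitrogen, on this same carbon would separate those two readings.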